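The source may hold more compounds than are shown below. What is called first, only, known or untested is meant among the compounds shown, and "the series" means these compounds.

Values so far in a functional assay on MCF7 cells (Homo sapiens) for cytotoxicity, read by sulforhodamine B assay, with a stated time of 2 days (a higher number here means a weaker inhibitor, a lower number a stronger inhibitor), for the series

- compound 1 `OC1CNCc2nc(-c3ccc(N4CCCC4)cc3)sc21` gives 1530 nM
- compound 2 `Cc1cc(N(C)C)ccc1-c1nc2c(s1)[C@H](O)CCC2` gives 730 nM

Of these two numbers, compound 2 holds the lower at 730 nM and compound 1 the higher at 1530 nM, a gap just beyond the scatter. The two compounds differ in more than one place, so this gap says nothing about any single change.

The next compound is compound 3 `Cc1cc(N(C)C)ccc1-c1nc2c(s1)[C@@H](O)CCC2`, which has the same atoms and bonds as compound 2. The difference is the two compounds have the same atoms and bonds and differ only in configuration as drawn: 1 of 1 stereo elements differ; a stereocentre at a saturated ring carbon is drawn R in compound 2 and S in compound 3 and nothing else: a stereocentre at a saturated ring carbon is drawn R in compound 2 and S in compound 3.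

Going by the values given here, no measured pair here isolates a change of configuration, so this assay offers no direct guide to the size of this step. Among the compounds with values here, a small upward step, possibly none beyond the scatter, is expected since compound 2 at 730 nM holds the lower of only two numbers. The estimated step is a 1.4-fold higher number from compound 2 to compound 3 (0.14 log units; within the scatter) and carries wide uncertainty. For compound 3 the expected value is 1000 nM, with an estimated range from 350 nM to 2800 nM.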

Compound 3, half-maximal inhibitory concentration: 2150 nM
Compound 3: the middle estimate sits 2.2-fold (0.33 log units) below what was measured; the measured number falls inside the stated range.
By their numbers in this assay, from the lowest: compound 2; then compounds 1 and 3 (each within the scatter of the next).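

Inverting the stereocentre at a saturated ring carbon, drawn R in one compound and S in the other, gives a 2.9-fold higher number from compound 2 to compound 3 (0.47 log units; beyond the scatter) in this assay, the first step in the series that can be read at a single place. The gap between the two earlier compounds could not be tied to any one change, whereas this step can be put down to configuration alone because of what separates the pair: the fact that compounds 2 and 3 differ only in the configuration as drawn The R drawing therefore gives the lower number at this stereocentre, although this rests on one pair with a single set of substituents on the shared core.

Going by these compounds, whether the same preference holds on the core of compound 1, whose corresponding carbon is drawn without configuration, remains open. Also open, on these data alone, is how this carbon behaves when the hydroxyl is replaced by a methoxy group or a ketone carbonyl, and whether the gap between the two drawings then stays, widens or disappears.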